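Boronic acid in place of the triazole arm

A few compounds are considered here, and "the series" means these few. Any claim that something is new, unique, unknown or untested is made for them only; others in the source may bear on it.

Compound 3 `O=C(NCc1ccc(OCc2cn(-c3ccccc3)nn2)cc1)[C@@H]1CCC(=O)N1Cc1ccccc1` stands at the edge of what an assay on HEK293 cells for inhibition of Ataxin-2 (Mus musculus), read by fluorescence and Amplex Red (on this read-out higher numbers stand for weaker inhibition and lower numbers for stronger inhibition), can report: in this assay compound 3 gives > 5000 nM, which is a limit and not a number. Compound 2 `O=C(NCc1ccc(O)cc1)[C@@H]1CCC(=O)N1Cc1ccccc1` likewise gives a limit, > 5000 nM. The step that the two limits leave unreadable from compound 2 to compound 3 is unreadable because the limit of > 5000 nM in this assay, at which 2 of the 3 values shown sit, holds both values. Compound 1 `CC1(C)OB(c2ccc(COc3ccc(CNC(=O)[C@@H]4CCC(=O)N4Cc4ccccc4)cc3)cc2)OC1(C)C` gives 50 nM in this assay. Compound 4 `O=C(NCc1ccc(OCc2ccc(B(O)O)cc2)cc1)[C@@H]1CCC(=O)N1Cc1ccccc1` differs from compound 3 by a group of 9 heavy atoms (6 carbon, 1 boron, 2 oxygen; one six-membered aromatic ring of carbon only) in place of a group of 11 heavy atoms (8 carbon, 3 nitrogen; one five-membered aromatic ring with 3 hetero atoms, one six-membered aromatic ring of carbon only), on a saturated chain carbon bound to an oxygen on an aromatic ring. Within the data shown here, no measured step covers this change; compound 1 carries a related boron-bearing group at the same place and gives a number, whereas compound 3 gives only a limit. The expected step is an at least 50-fold lower number from compound 3 to compound 4 (1.69 log units; beyond the scatter), toward stronger inhibition. Compound 4 is estimated at 100 nM, within 20 nM to 1500 nM.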

Compound 4, half-maximal inhibitory concentration: 35 nM
The estimate for compound 4 lay 2.9-fold (0.46 log units) above the measured number; low and high end bracket the measured number.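

In this assay, the boron-bearing arm on the saturated chain carbon bound to an oxygen on an aromatic ring gives an at least 140-fold lower number from compound 3 to compound 4 (2.15 log units; beyond the scatter), and placing the whole arm on the free oxygen gives an at least 140-fold lower number from compound 2 to compound 4 (2.15 log units; beyond the scatter) as a second bound. Both sizes are only bounds because compounds 2 and 3 each sit at a limit: the limit of > 5000 nM in this assay, at which 2 of the 4 values shown sit. The step of a 1.4-fold lower number from compound 1 to compound 4 (0.15 log units; within the scatter) leaves the boronic ester and the free boronic acid unseparated on this arm.

Open, on these data alone, is whether a carboxylic acid or an amine in place of the boronic acid would keep a readable number. Also open, as far as these compounds go, is how a longer chain at this oxygen would read.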